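Swapping the dichlorophenyl arm for a bromo-fluoro pattern

The compounds below may be only part of what the source reports. "The series", "measured", "known", "first", "only" and "open" are said of these compounds alone.

Measured compounds:
- compound 1 `C=CCn1c(=O)/c(=C\c2cccc(Cl)c2Cl)[nH]c(=O)/c1=C\c1ccccc1OC`: 1600 nM
- compound 2 `C=CCn1c(=O)/c(=C\c2ccc(Cl)c(Cl)c2)[nH]c(=O)/c1=C\c1ccccc1OC`: "not active" (no number reported)
- compound 3 `C=CCn1c(=O)/c(=C\c2ccccc2C(F)(F)F)[nH]c(=O)/c1=C\c1ccccc1OC`: 4600 nM

Three compounds share one core and differ only in the aryl group on a double-bonded chain carbon bound to an aromatic carbon. In a functional assay on HeLa cells (Homo sapiens) for cytotoxicity, read by CCK-8 assay, with a stated time of 72 h (on this read-out higher numbers stand for weaker inhibition and lower numbers for stronger inhibition), compound 1 gives the lowest of the two reported numbers. Compound 3, with a 2-(trifluoromethyl)phenyl there, gives 4600 nM, and the step of a 2.9-fold higher number from compound 1 to compound 3 (0.46 log units; beyond the scatter) lies beyond the scatter. Compound 2, with a 3,4-dichlorophenyl, is reported in this assay only as "not active" (no number reported), without a number.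

Compound 4 `C=CCn1c(=O)/c(=C\c2ccc(F)c(Br)c2)[nH]c(=O)/c1=C\c1ccccc1OC` carries the change (3-bromo-4-fluorophenyl in place of 2,3-dichlorophenyl on a double-bonded chain carbon bound to an aromatic carbon). For the measured compounds named here, no measured step covers exactly this exchange. Going by the values given here, the only step that touches the same place, from compound 1 to compound 3, made the number modestly higher, and compound 2 shows that a 3,4-substituted aryl at this place gave no measurable activity at all. Compound 4 is therefore expected to lie well above compound 1, with a real chance that only a limit is reported. The estimated step is a 5.0-fold higher number from compound 1 to compound 4 (0.70 log units; beyond the scatter). For compound 4 the expected value in this assay is 8000 nM, with a range from 2500 nM to 30000 nM.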

Compound 4, half-maximal inhibitory concentration: "not active" (no number reported)
Compound 4: no number reported; no gap can be computed for the estimate.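

For the compounds shown here, compound 4, like compound 2, is reported in this assay only as "not active", without a number, so no new step from compound 1 can be read. No measurement shown explains this result. The compounds shown leave open how far compound 2 and compound 4 lie from compound 1.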